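The compounds below may be only part of what the source reports. "The series", "measured", "known", "first", "only" and "open" are said of these compounds alone.

Compound 1 `CN1CCN(c2ccc(Nc3ncc4nc(Nc5ccc(F)cc5)n([C@@H]5CCN(C(=O)CO)C5)c4n3)cc2)CC1` — "not determined" (no result reported)
Compound 2 `CN1CCN(c2ccc(Nc3ncc4nc(Nc5ccc(F)cc5)n([C@H]5CCCN(S(=O)(=O)C6CC6)C5)c4n3)cc2)CC1` — 1150 nM

The study follows a pair of compounds built on one shared core and differing only in the group carried on an aromatic nitrogen of the core. Compound 1 stands without a number: in a functional assay on NCI-H1975 cells (Homo sapiens) for antiproliferative activity, read by MTT assay, with a stated time of 72 h (a lower number here means a stronger inhibitor, a higher number a weaker inhibitor), compound 1 gives "not determined" (no result reported), so its place on the scale cannot be stated. Among the measured compounds shown here, compound 2 is the only measured point, and in this assay compound 2 gives 1150 nM; no step between compound 1 and compound 2 is recorded, so their relation is not known.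

Compound 3 `CN1CCN(c2ccc(Nc3ncc4nc(Nc5ccc(F)cc5)n(-c5cccc(NC(=O)CO)c5)c4n3)cc2)CC1` is the compound yet to be measured. It differs from compound 1 in one place: 3-(((hydroxymethyl)carbonyl)amino)phenyl in place of 1-((hydroxymethyl)carbonyl)pyrrolidin-3-yl on an aromatic nitrogen. For the measured compounds named here, with no number for compound 1 and no recorded step, the size of the change cannot be derived; the expectation rests on compound 2 alone, whose value of 1150 nM sets the scale on which compound 3 is likely to fall. For compound 3 in this assay the estimate is 600 nM, within a range from 100 nM to 4000 nM.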

Compound 3, half-maximal inhibitory concentration: 580 nM
Compound 3: middle estimate off by 1.0-fold (0.01 log units), on the high side, and the stated range covers the measured number.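

In this assay this position now has its first readable comparison, a 2.0-fold lower number from compound 2 to compound 3 (0.30 log units; within the scatter), so the two groups cannot be told apart on this measure. A 3-(((hydroxymethyl)carbonyl)amino)phenyl group, with its six-membered aromatic ring of carbon only, thus stands on the aromatic nitrogen in place of 1-(cyclopropylsulfonyl)piperidin-3-yl with no change beyond the scatter, while the step from compound 1 to compound 3 cannot be read, as compound 1 has no number. No measurement bearing on the reason for this result is available.

The compounds shown leave open whether a phenyl group with no substituent, or a phenyl group carrying an amine or a carboxylic acid in place of the ((hydroxymethyl)carbonyl)amino group, would give a number apart from these in this assay. Compound 2 and compound 3 also differ in both the ring and the group it carries, so the part played by each alone remains unresolved, and a piperidin-3-yl group bearing the same (hydroxymethyl)carbonyl group would be needed to separate them.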